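The compounds below may be only part of what the source reports. "The series", "measured", "known", "first", "only" and "open" are said of these compounds alone.

Compound 3 `COc1cccc([C@]2(CO)NC[C@@H](O)[C@@H]2O)c1` is the weakest of the three measured compounds on the numbers shown: in an assay on isolated protein for inhibition of lysosomal alpha-glucosidase (Rattus norvegicus), read by colorimetric assay (a higher number here means a weaker inhibitor, a lower number a stronger inhibitor), compound 3 gives 52000 nM. The parent compound 1 `OC[C@]1(c2ccccc2)NC[C@H](O)[C@H]1O` is far stronger, with compound 1 giving 190 nM in this assay, while the fluoro analogue compound 2 `OC[C@]1(c2cccc(F)c2)NC[C@H](O)[C@H]1O` gives 43000 nM, which sits within the scatter of compound 3. Going by the values given here, the only step documented is a 230-fold higher number from compound 1 to compound 2 (2.35 log units; beyond the scatter), a large loss brought by a fluoro in place of hydrogen on an aromatic carbon.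

Compound 4 `COc1cccc([C@@]2(CO)NC[C@H](O)[C@H]2O)c1` is reached from compound 3 by the two compounds have the same atoms and bonds and differ only in configuration as drawn: 3 of 3 stereo elements differ (all stereocentres are inverted: mirror images); a stereocentre at a saturated ring carbon is drawn R in compound 3 and S in compound 4; a stereocentre at a saturated ring carbon is drawn R in compound 3 and S in compound 4; a stereocentre at a saturated ring carbon is drawn R in compound 3 and S in compound 4. Among the compounds with values here, no measured step addresses a mirror-image change, and the step from compound 1 to compound 2 concerns a substituent rather than configuration, so it bears on this move only indirectly. What can be said is that compound 4 is drawn with the same configuration as compounds 1 and 2, and that compound 2, with a small aromatic substituent in that series, still gave 43000 nM. A modest improvement is therefore expected rather than a return to the level of compound 1. Compound 4 is estimated at 15000 nM in this assay, within a range of 1500 nM to 100000 nM, meaning an expected step of a 3.5-fold lower number from compound 3 to compound 4 (0.54 log units; beyond the scatter).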

Compound 4, half-maximal inhibitory concentration: 108000 nM
The estimate for compound 4 lay 7.2-fold (0.86 log units) below the measured number, outside the stated range (above it).
By their numbers in this assay, from the lowest: compound 1; then compounds 2 and 3 (each within the scatter of the next); then compound 4.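

With a 2.1-fold higher number from compound 3 to compound 4 (0.32 log units; beyond the scatter) in this assay, the set gains its first reading of a full inversion of configuration, a modest step that can be laid to configuration alone because of what separates the pair: the fact that compounds 3 and 4 differ only in the configuration as drawn. Within the configuration of compound 1, the change at the aromatic carbon can now be read for a second substituent: a 570-fold higher number from compound 1 to compound 4 (2.75 log units; beyond the scatter) is a large loss, like the one already seen for fluoro, while a 2.5-fold higher number from compound 2 to compound 4 (0.40 log units; beyond the scatter) shows only a modest further rise on going to methoxy. Neither of the two substituted compounds in that configuration, nor compound 3 in the inverted one, comes near compound 1, so inverting the configuration did not restore the strength lost with the methoxy group, and compound 4 is the weakest of the four.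

Whether the unsubstituted aromatic ring of compound 1 depends on configuration as little as the methoxy pair does remains open, since its mirror image is absent from the compounds shown. Also open, from the compounds shown here alone, is whether an amine or a carboxylic acid on that aromatic carbon would lose as much as fluoro and methoxy do.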